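This account rests on a few compounds, and the source may have more. Where it says the series, first, only, none or still open, it means among the compounds named here.

Measured so far:
compound 1, `CCCCCCC#Cc1ccc(S(=O)(=O)Nc2cccc(-c3csc(NC(C)=O)n3)c2)cc1`, in a functional assay on A-375 cells (Homo sapiens) for antiproliferative activity, read by trypan blue exclusion, with a stated time of 48 h, tested at 5 uM; on this read-out higher numbers stand for a weaker effect at the one concentration tested and lower numbers for a stronger effect: 12.8%
compound 2, `CC(=O)Nc1nc(-c2cccc(NS(=O)(=O)c3ccc(Br)cc3)c2)cs1`, in this assay: 19.7%

Compound 1 gives the lowest of the two numbers in this assay, and its nearest neighbour is compound 2, with a number 6.9 percentage points higher from compound 1 to compound 2 (within the scatter); that step exchanges bromo for oct-1-yn-1-yl on an aromatic carbon and so does not separate the two compounds beyond the scatter. Compound 3, `CCCCCCC#Cc1ccc(S(=O)(=O)Nc2cccc(-c3csc(NC)n3)c2)cc1`, has not yet been measured. It differs from compound 1 as follows: methyl in place of acetyl on a nitrogen on an aromatic ring. Among the measured compounds shown here, no measured step touches this nitrogen on the aromatic ring; the only known step concerns a different position of the shared core, so nothing measured bears directly on the change. The expectation for compound 3 therefore rests on compound 1 alone, and the step of a number 9.2 percentage points higher from compound 1 to compound 3 (within the scatter) is expected to stay within or near the scatter, with a wide range to reflect the missing precedent. Compound 3 is estimated at 22%, between 8% and 50%.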

Compound 3, a percentage reported as activity, at one concentration (the size of the read-out at that concentration, not a potency): 8.1%
For compound 3 the middle estimate is 13.9 percentage points above the measured one, and the stated range covers the measured number.
By their numbers in this assay, from the lowest: compounds 3, 1 and 2 (each within the scatter of the next, the first and the last beyond it).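

In this assay, among the compounds shown here, the exchange of acetyl for methyl on a nitrogen on an aromatic ring gives a number 4.7 percentage points lower from compound 1 to compound 3 (within the scatter), the first measured step at this position. With oct-1-yn-1-yl kept in place, the read-out therefore does not depend on the acetyl group, and the smaller methyl, with no hydrogen-bond acceptor of its own, serves equally well within the scatter. Nothing available accounts for this tolerance.

Going by these compounds, whether a free amine, an ethyl group or a longer acyl chain on this nitrogen would also stay within the scatter remains open. So does whether methyl in place of acetyl would give a similar step with bromo in place of oct-1-yn-1-yl. The read-out comes from a single concentration and so speaks only of a stronger or weaker effect at that concentration.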